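The compounds below may be only part of what the source reports. "The series", "measured", "known", "first", "only" and "open" are said of these compounds alone.

Going by the values given here, in an ADME assay on HepG2 cells (Homo sapiens) for inhibition, with a stated time of 48 h (on this read-out lower numbers stand for an effect already at smaller amounts and higher numbers for an effect only at larger amounts of compound), the three compounds measured so far all act only at the upper edge of what the assay can report. Compound 1 `C[C@@H](C(=O)N1CCC(F)(F)CC1)N1CCN(S(=O)(=O)c2ccc(C(C)(C)C)cc2)CC1` gives > 40000 nM, which is a limit of the assay rather than a number. Compound 3 `CC(C(=O)N1CCc2ccccc2C1(C)C)N1CCN(S(=O)(=O)c2ccc(C(C)(C)C)cc2)CC1` gives 31000 nM, a measured number close to that edge. Compound 2 `CC(C(=O)N1CCC2(CC1)CC2)N1CCN(S(=O)(=O)c2ccc(C(C)(C)C)cc2)CC1` gives > 40000 nM, again a limit and not a number. Compound 2 thus stands at the limit of > 40000 nM in this assay, at which 2 of the 3 values shown sit, and nothing in the shown values places it apart from the others.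

Compound 4 `CC(C(=O)N1CCc2ncccc2C1)N1CCN(S(=O)(=O)c2ccc(C(C)(C)C)cc2)CC1` has not yet been measured in this assay. It differs from compound 2 in one place: a group of 10 heavy atoms (8 carbon, 2 nitrogen; one six-membered non-aromatic ring with 1 hetero atom, one six-membered aromatic ring with 1 hetero atom) in place of a group of 8 heavy atoms (7 carbon, 1 nitrogen; one three-membered non-aromatic ring of carbon only, one six-membered non-aromatic ring with 1 hetero atom), on a carbonyl carbon. The shared core, the sulfonyl-linked part and the chain carbon next to the carbonyl stay as they are.

Among the compounds with values here, since every measured value here sits at or near the limit, and no step between measured compounds is available, no shift beyond the usual scatter is expected from this change. The expected step is a step that the limit leaves unreadable from compound 2 to compound 4, which would mean no real movement. Compound 4 is therefore estimated to give about 45000 nM in this assay, with a likely range from 25000 nM to 100000 nM, and it will most probably again be reported only as a limit.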

Compound 4, half-maximal effective concentration: > 40000 nM
Compound 4 gave a limit, no number; the forecaster's own chance of this, stated with the estimate: 70%; the middle value does not contradict the limit.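

Compound 2 and compound 4 both stand only as limits in this assay, not as numbers, so no step can be read between them. The compounds shown leave open where the true values of these two compounds lie, and whether exchanging the group on the carbonyl carbon changes the read-out at all.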